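Notes on a fluoro change to compound 1

The compounds below may be only part of what the source reports. "The series", "measured", "known", "first", "only" and "open" are said of these compounds alone.

Measured compounds in a functional assay on VCaP cells (Homo sapiens) for antiproliferative activity, read by CCK-8 assay, with a stated time of 6 days; on this read-out higher numbers stand for weaker inhibition and lower numbers for stronger inhibition
- compound 1 `C[C@@H](Cn1ccc(-c2ccc(C#N)c(Cl)c2)n1)NC(=O)c1ccccc1` gives "not determined" (no result reported)
- compound 2 `CC(O)c1cccc(C(=O)N[C@@H](C)Cn2ccc(-c3ccc(C#N)c(Cl)c3)n2)c1` gives 900 nM
- compound 3 `CC(=O)c1ccc(C(=O)N[C@@H](C)Cn2ccc(-c3ccc(C#N)c(Cl)c3)n2)cc1` gives 1400 nM

Compound 1 has no single number in this assay and so offers no starting value. Compound 4 `C[C@@H](Cn1ccc(-c2ccc(C#N)c(Cl)c2)n1)NC(=O)c1ccccc1F` differs from compound 1 by fluoro in place of hydrogen on an aromatic carbon, ortho to a large group. Among the compounds with values here, the only measured step (a 1.6-fold higher number from compound 2 to compound 3 (0.19 log units; within the scatter)) lies within the scatter and involves other groups, so it does not size this change. Within the data shown here, no step can therefore be predicted, and the expectation rests on the level of compound 2 (900 nM) and compound 3 (1400 nM). Compound 4 is expected near 1500 nM with an estimated range of 500 nM to 5000 nM in this read-out.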

Compound 4, half-maximal inhibitory concentration: 2190 nM
For compound 4 the middle estimate is 1.5-fold (0.16 log units) below the measured one; the range from low to high includes it.
By their numbers in this assay, from the lowest: compounds 2, 3 and 4 (each within the scatter of the next, the first and the last beyond it).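

In this assay, within the data shown here, compound 4 gives 2190 nM and supplies the first number for a 2-fluorophenyl on this carbonyl. The comparisons give a 1.6-fold higher number from compound 3 to compound 4 (0.19 log units; within the scatter) and also a 2.4-fold higher number from compound 2 to compound 4 (0.39 log units; beyond the scatter) so only the gap to compound 2 clears the scatter, and each step replaces the whole aryl group, not fluoro alone. Going by these compounds, the step from compound 1 to compound 4 cannot be read, so the size of the fluoro change itself stays unknown.

On these data alone, whether an amine or a carboxylic acid in place of fluoro would give a different number stays open. No evidence on the cause of this result is at hand.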